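The compounds below may be only part of what the source reports. "The series", "measured", "known", "first", "only" and "open" are said of these compounds alone.

Working notes on the series. In a physicochemical assay for solubility, using the shake flask method, in simulated intestinal fluid, measured as kinetic solubility, with a stated time of 2 h, at 25 degrees C, at pH 6.5 (on this read-out higher numbers stand for higher solubility and lower numbers for lower solubility), compound 1 (`CCOC(=O)c1nc(C)c2c(c1N)C(=O)N(Cc1ccccc1)C2=O`) gives < 5000 nM, which is a limit and not a number. Compound 2 (`Cc1nc(C#N)c(N)c2c1C(=O)N(Cc1ccccc1)C2=O`) gives < 5000 nM, also a limit. Compound 3 (`Cc1nc(C(N)=O)c(N)c2c1C(=O)N(Cc1ccccc1)C2=O`) gives < 5000 nM, again a limit. Compound 1 therefore has no numerical position in the series, and the whole measured set is summed up as the limit of < 5000 nM in this assay, at which 3 of the 3 values shown sit.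

Compound 4 (`CCOC(=O)c1nc(C)c2c(c1N)C(=O)N(c1ccccc1)C2=O`) carries phenyl in place of benzyl on an amide-type nitrogen in a ring.

Three measured steps are available: a step that the two limits leave unreadable from compound 1 to compound 2, a step that the two limits leave unreadable from compound 1 to compound 3 and a step that the two limits leave unreadable from compound 2 to compound 3. None of them replaces benzyl, and none has a readable size, so they give no direct measure for this change. They show only that three variations at another place all end at the same limit. On that basis, no direction can be assigned, and no change beyond the scatter is expected in this assay. The expected change is a step that the limit leaves unreadable from compound 1 to compound 4. A further report as a limit is the likeliest outcome, resting on (the limit of < 5000 nM in this assay, at which 3 of the 3 values shown sit). For compound 4 the estimated value is 3000 nM, with an expected range from 1000 nM to 6000 nM.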

Compound 4, solubility: 5000 nM
Compound 4: the middle estimate sits 1.7-fold (0.22 log units) below what was measured; measured number inside the range.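

In this assay, going by these compounds alone, phenyl in place of benzyl on an amide-type nitrogen in a ring gives a number no lower from compound 1 to compound 4 (the limit leaves the size open), the first change to return a number rather than a limit. Going by these compounds, this nitrogen is therefore a place where a single replacement can yield a readable value, which the three variations at another place did not do, although the size of this step stays open. Compound 4 is the only readable value so far, and every other compound shown remains a limit: the limit of < 5000 nM in this assay, at which 3 of the 4 values shown sit.

Compound 1 has only a limit, so how far compound 4 stands from it cannot be stated, and a single replacement at this nitrogen defines no trend. Still open, on these data alone, is how a longer chain such as phenethyl, or a benzyl group carrying an amine or a carboxylic acid, would read on this nitrogen in this assay, and whether phenyl here would also return a number when paired with the nitrile of compound 2 or the carbamoyl of compound 3.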